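Naphthyl to chlorophenyl on the cyanopyridine of compound 1

The compounds below may be only part of what the source reports. "The series", "measured", "known", "first", "only" and "open" are said of these compounds alone.

Within the data shown here, compound 1 `Cn1cncc1C(OCc1ccc(C#N)c(-c2ccc3ccccc3c2)n1)c1ccc(C#N)cc1` is the only member of the series with a numerical result in an assay on isolated protein (Bos taurus) for inhibition of geranylgeranyl transferase type-1 subunit beta (Homo sapiens) (on this read-out lower numbers stand for stronger inhibition and higher numbers for weaker inhibition), where compound 1 gives 2600 nM. Compound 2 `Cn1cncc1C(OCc1ccc(C#N)cc1-c1cc(F)cc(F)c1)c1ccc(C#N)nc1` in this assay returns only a limit, > 10 nM. Compound 3 `Cn1cncc1C(OCc1ccc(C#N)nc1-c1ccccc1)c1ccc(C#N)cc1` likewise returns only a limit, > 10 nM. Two of the three results therefore sit at the limit of > 10 nM in this assay, at which 2 of the 3 values shown sit, so compound 1 cannot be ranked against the others. Compound 4 `Cn1cncc1C(OCc1ccc(C#N)c(-c2ccc(Cl)cc2)n1)c1ccc(C#N)cc1` carries 4-chlorophenyl in place of naphthalen-2-yl on an aromatic carbon, a 4-chlorophenyl in place of naphthalen-2-yl on an aromatic carbon. Among the measured compounds shown here, no measured pair isolates this exchange, so the step is expected to stay within the scatter or move modestly in either direction; the estimated step of a 1.2-fold higher number from compound 1 to compound 4 (0.06 log units; within the scatter) is taken as small. Compound 4 is expected to give about 3000 nM in this assay, within 800 nM to 12000 nM.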

Compound 4, half-maximal inhibitory concentration: 3900 nM
For compound 4 the middle estimate is 1.3-fold (0.11 log units) below the measured one, and the stated range covers the measured number.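

In this assay, the exchange at this aromatic carbon gives a 1.5-fold higher number from compound 1 to compound 4 (0.18 log units; within the scatter). Among these compounds, this is the first readable pair: with 4-chlorophenyl in place of naphthalen-2-yl, the position holds one six-membered aromatic ring of carbon only with no change beyond the scatter.

Going by these compounds, whether this position also accepts an amine, a carboxylic acid or a longer chain remains open. Compounds 2 and 3 still cannot be ranked against compound 1 or compound 4, as their results are limits: the limit of > 10 nM in this assay, at which 2 of the 4 values shown sit.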